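The source may hold more compounds than are shown below. What is called first, only, known or untested is meant among the compounds shown, and "the series" means these compounds.

Compound 1 `CC[C@]1(c2ccc(Cl)cc2)OC[C@H]([C@@H]2CCCCN2)O1`: 2800 nM in a functional assay (brain) for displacement of a labelled ligand, with Rattus norvegicus as the target; on this read-out lower numbers stand for stronger inhibition and higher numbers for weaker inhibition
Compound 2 `CC[C@]1(c2ccc(O)cc2)OC[C@H]([C@@H]2CCCCN2)O1`: 19900 nM
Compound 3 `CC[C@]1(c2ccc(F)cc2)OC[C@H]([C@@H]2CCCCN2)O1`: not yet measured

In this assay, for the measured compounds named here, compound 2 gives the higher of the two numbers so far; the only other point is compound 1 at 2800 nM. Going by the values given here, the one measured step, a 7.1-fold higher number from compound 1 to compound 2 (0.85 log units; beyond the scatter), came with hydroxy in place of chloro. Compound 3 differs from compound 2 by fluoro in place of hydroxy on an aromatic carbon, largely reversing that earlier change with another halogen. The step is therefore expected to lower the number beyond the scatter, roughly a 5.0-fold lower number from compound 2 to compound 3 (0.70 log units; beyond the scatter). Compound 3 is estimated at 4000 nM, within 1500 nM to 12000 nM.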

Compound 3, inhibition constant: 649 nM
Estimate against measurement, compound 3: 6.2-fold (0.79 log units) above; the measured number lies below the stated range.
By their numbers in this assay, from the lowest: compound 3; then compound 1; then compound 2.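

In this assay fluoro in place of hydroxy gives a 31-fold lower number from compound 2 to compound 3 (1.49 log units; beyond the scatter) and so does more than undo the earlier rise on going from chloro to hydroxy. The two halogens also differ at this position: fluoro in place of chloro gives a 4.3-fold lower number from compound 1 to compound 3 (0.63 log units; beyond the scatter) and places compound 3 lowest of the three. Nothing available here accounts for this order.

The compounds shown leave open how bromo, methoxy or an amine would read at this position on the same core, and whether hydrogen there would sit nearer to fluoro or to hydroxy.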